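The source may hold more compounds than are shown below. What is called first, only, known or untested is meant among the compounds shown, and "the series" means these compounds.

In a functional assay on A549 cells (Homo sapiens) for antiproliferative activity, read by MTT assay, with a stated time of 72 h (on this read-out higher numbers stand for weaker inhibition and lower numbers for stronger inhibition), compound 1 (`COc1cc2ncnc(Nc3ccc(F)c(Br)c3)c2cc1OCCCN1CCNCCNCCNCC1`) gives 11800 nM, the higher of the two actual numbers, while compound 2 (`COc1cc2ncnc(Nc3ccc(OCc4cccc(F)c4)c(Cl)c3)c2cc1OCCCN1CCNCCNCCNCC1`) gives 3400 nM, a lower number beyond the scatter. In this assay compound 3 (`COc1cccc(Nc2ncnc3cc(OC)c(OCCCN4CCNCCNCCNCC4)cc23)c1`) is reported only as a limit, > 50000 nM. Compound 4 (`COc1cc2ncnc(Nc3cccc(F)c3)c2cc1OCCCN1CCNCCNCCNCC1`) carries 3-fluorophenyl in place of 3-bromo-4-fluorophenyl on a nitrogen on an aromatic ring. Going by the values given here, the one measured step at this place is an at least 4.2-fold higher number from compound 1 to compound 3 (0.62 log units; beyond the scatter), with 3-methoxyphenyl entering. Going by these compounds, it lies beyond the scatter, and its true size stays open, set by the limit of > 50000 nM in this assay, at which 1 of the 3 values shown sits. Weaker inhibition is therefore expected here too, and the estimated change is a 2.4-fold higher number from compound 1 to compound 4 (0.38 log units; beyond the scatter). Compound 4 is expected at about 28000 nM, within an estimated range of 12000 nM to 65000 nM.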

Compound 4, half-maximal inhibitory concentration: > 50000 nM
Compound 4: only a limit was reported; the forecaster's own chance of this, stated with the estimate: 35%; at least 1.7-fold (0.25 log units) between middle value and limit.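

With 3-fluorophenyl as well as 3-methoxyphenyl, a second replacement for 3-bromo-4-fluorophenyl on this nitrogen weakens inhibition, an at least 4.2-fold higher number from compound 1 to compound 4 (0.62 log units; beyond the scatter), so the loss is not confined to the methoxy group of compound 3. Compound 4 is reported only as a limit, > 50000 nM. The steps between compound 3 and compound 4 cannot be read, so fluoro and methoxy cannot be ranked here: the limit of > 50000 nM in this assay, at which 2 of the 4 values shown sit.

A phenyl ring carrying bromine alone would help separate the parts played by the bromine and the fluorine. Going by these compounds, how much weaker compound 4 truly is stays open.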